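A few compounds are considered here, and "the series" means these few. Any claim that something is new, unique, unknown or untested is made for them only; others in the source may bear on it.

Compound 1 `C/C(COc1ccc2c(=O)cc(-c3ccccc3)oc2c1)=N\O` was tested in a functional assay on SK-HEP1 cells (Homo sapiens) for antiproliferative activity (a higher number here means a weaker inhibitor of growth, a lower number a stronger inhibitor of growth), where compound 1 gives 2800000 nM. Among the three compounds measured so far, this places compound 1 second highest. Compound 3 `CO/N=C(\C)COc1ccc2c(=O)c(-c3ccccc3)coc2c1` gives 6400000 nM, a higher number than compound 1 by a margin beyond the usual scatter, while compound 2 `CO/N=C(\C)COc1ccc2oc(-c3ccccc3)cc(=O)c2c1` gives 800000 nM, a lower number than compound 1, again by a margin beyond the scatter. Compound 4 `O=c1cc(-c2ccccc2)oc2cc(OC/C(=N/O)c3ccc(F)cc3)ccc12` has not yet been measured in this assay. Its difference from compound 1 is 4-fluorophenyl in place of methyl on a carbon with a double bond to nitrogen, in words a 4-fluorophenyl in place of methyl on a carbon with a double bond to nitrogen. Within the data shown here, no step between two measured compounds covers a change of this kind, so the data give nothing that fixes its size or direction. The expectation is a modest move toward a lower number, with the step from compound 1 to compound 4 estimated at a 3.1-fold lower number from compound 1 to compound 4 (0.49 log units; beyond the scatter). Compound 4 is therefore expected to give about 900000 nM in this assay, within a range from 200000 nM to 4000000 nM.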

Compound 4, concentration for 50% growth inhibition: 2300000 nM
Estimate against measurement, compound 4: 2.6-fold (0.41 log units) below, and the stated range covers the measured number.
By their numbers in this assay, from the lowest: compound 2; then compounds 4 and 1 (each within the scatter of the next); then compound 3.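

In this assay, among these compounds, this is the first reading at the carbon with a double bond to nitrogen: a 1.2-fold lower number from compound 1 to compound 4 (0.09 log units; within the scatter), a step within the usual scatter. A 4-fluorophenyl in place of methyl brings in a whole six-membered aromatic ring of carbon only, yet the two compounds cannot be told apart in this assay, so this position tolerates a much larger group here without a measurable gain or loss. No measured evidence for these compounds bears on why this is so.

Open, going by these compounds, is whether that tolerance extends to other groups at this place, such as plain phenyl, a longer alkyl chain or a chain ending in an amine. Also open, on these data alone, is whether the same exchange would give a similar step on the cores of compound 2 and compound 3.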